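The source may hold more compounds than are shown below. What is called first, only, known or untested is meant among the compounds shown, and "the series" means these compounds.

Compound 2 `COc1cccc(C(=O)N/N=C/C2=C(Cl)c3cc(C)c(C)cc3CCC2)c1C` in a functional assay on IMR-32 cells (Homo sapiens) for inhibition, read by sulforhodamine B assay, with a stated time of 48 h (a higher number here means a weaker inhibitor of growth, a lower number a stronger inhibitor of growth), gives 170 nM. For the measured compounds named here, the only comparison on hand is compound 1 `Cc1ccc(C(=O)N/N=C/C2=C(Cl)c3cc(C)c(C)cc3CCC2)cc1`, which in this assay gives 100 nM; the step of a 1.7-fold higher number from compound 1 to compound 2 (0.23 log units; within the scatter) keeps the two within the scatter. Compound 3 `Cc1cc2c(cc1C)C(Cl)=C(/C=N/NC(=O)c1ccccc1N)CCC2` differs from compound 2 by 2-aminophenyl in place of 3-methoxy-2-methylphenyl on a carbonyl carbon. Going by the values given here, the one measured step bearing on this, a 1.7-fold higher number from compound 1 to compound 2 (0.23 log units; within the scatter), is likewise an exchange of the aryl group on the carbonyl carbon and stayed within the scatter, so no step beyond the scatter is expected in this assay for compound 3, whose estimate is 170 nM (range 60 nM to 500 nM), an expected step of no change at the digits printed from compound 2 to compound 3 (within the scatter).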

Compound 3, concentration for 50% growth inhibition: 36300 nM
Beside the measured number, compound 3's estimate is 210-fold (2.33 log units) below it; measured number outside the range, above it.
By their numbers in this assay, from the lowest: compounds 1 and 2 (each within the scatter of the next); then compound 3.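

In this assay this place on the carbonyl carbon proves far from indifferent: 2-aminophenyl brings a 210-fold higher number from compound 2 to compound 3 (2.33 log units; beyond the scatter) and also a 360-fold higher number from compound 1 to compound 3 (2.56 log units; beyond the scatter), whereas the exchange of 4-methylphenyl for 3-methoxy-2-methylphenyl stayed within the scatter. Of the three aryl groups shown, only 2-aminophenyl carries a hydrogen-bond donor, but three compounds cannot tie the loss to that count. Nothing on hand accounts for the loss.

Going by these compounds, whether the amine itself drives this step remains open. A hydroxyl, an acetylated amine or an unsubstituted phenyl at this place would bear on that question.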